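One added methyl from compound 2 to compound 3

The source may report more compounds than this note shows. Statements on the series, on what has been measured and on what is new or still open speak of the compounds shown alone.

Of the compounds shown here, two that share one core have so far been read in an ADME assay on microsomes from liver (Mus musculus) for metabolic stability, with a stated time of 10 min; on this read-out higher numbers stand for a more stable compound and lower numbers for a less stable compound. There compound 1 (`CCc1ccc(S(=O)(=O)[C@@]2(c3ccc(C(F)(C(F)(F)F)C(F)(F)F)cc3)CCN(C(=O)[C@H]3CC[C@H](C(=O)O)CC3)C2)cc1`) gives 100% and compound 2 (`Cc1cc(S(=O)(=O)[C@@]2(c3ccc(C(F)(C(F)(F)F)C(F)(F)F)cc3)CCN(C(=O)[C@H]3CC[C@H](C(=O)O)CC3)C2)ccc1F`) gives 84%, so compound 2 holds the lower of the two numbers. Among the measured compounds shown here, the one measured step shows a number 16 percentage points lower from compound 1 to compound 2 (beyond the scatter), a modest change that came with 4-fluoro-3-methylphenyl in place of 4-ethylphenyl on a sulfonyl sulfur.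

Compound 3 (`CCc1cc(S(=O)(=O)[C@@]2(c3ccc(C(F)(C(F)(F)F)C(F)(F)F)cc3)CCN(C(=O)[C@H]3CC[C@H](C(=O)O)CC3)C2)ccc1F`) differs from compound 2 by methyl in place of hydrogen on a saturated chain carbon bound to an aromatic carbon, which turns 4-fluoro-3-methylphenyl into 3-ethyl-4-fluorophenyl. The measured step bears on this only loosely, since it exchanged a whole group and no measurement isolates one added methyl. Still, compound 1 carries an ethyl group and reads 100%, so the new ethyl gives no reason to expect a large fall. No change beyond the scatter is expected, and the expected step is a number 2 percentage points lower from compound 2 to compound 3 (within the scatter). The estimate for compound 3 is 82%, with an expected range of 65% to 97%.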

Compound 3, percent of the compound remaining: 73%
For compound 3 the middle estimate is 9 percentage points above the measured one; the range from low to high includes it.
By their numbers in this assay, from the lowest: compound 3; then compound 2; then compound 1.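

In this assay, the change from 4-fluoro-3-methylphenyl to 3-ethyl-4-fluorophenyl gives a number 11 percentage points lower from compound 2 to compound 3 (beyond the scatter) and so shows that one added methyl, on a saturated chain carbon bound to an aromatic carbon, can by itself move this read-out beyond the usual scatter. An ethyl group does not guarantee a high number: compound 1, with 4-ethylphenyl, gives 100% in this assay, yet placing 3-ethyl-4-fluorophenyl on the sulfonyl sulfur instead brings a number 27 percentage points lower from compound 1 to compound 3 (beyond the scatter) for the same shared core. Nothing measured here explains why the number falls with either change.

The compounds shown leave open whether a longer chain at this place, such as propyl, would lower the number further, or whether a methoxy group of similar size would behave like the ethyl group. They also leave open how a 3-ethylphenyl group without the fluorine would read, and that compound would help separate the part played by the fluorine from the part played by where the ethyl group sits.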